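Series notes: aryl exchange on the carbonyl carbon

This account rests on a few compounds, and the source may have more. Where it says the series, first, only, none or still open, it means among the compounds named here.

Compound 1 `COc1cc(-c2cc(/C=C/C(=O)c3ccc(N)cc3)[nH]n2)cc(OC)c1OC` carries the amino group on an aromatic carbon; in a functional assay on Malme-3M cells (Homo sapiens) for cytotoxicity, read by sulforhodamine B assay, with a stated time of 48 h, tested at 1 uM (on this read-out higher numbers stand for a weaker effect at the one concentration tested and lower numbers for a stronger effect), compound 1 gives 93%. Compound 2 `COc1ccc(C(=O)/C=C/c2cc(-c3cc(OC)c(OC)c(OC)c3)n[nH]2)cc1` carries a methoxy there instead; in this assay compound 2 gives 93%. Among the compounds with values here, the step of no change at the digits printed from compound 1 to compound 2 (within the scatter) was flat, so on the numbers so far compound 2 stands level with compound 1, both at the weak end of the read-out.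

Compound 3 `COc1cc(-c2cc(/C=C/C(=O)c3ccc(F)c(F)c3)[nH]n2)cc(OC)c1OC` differs from compound 2 by 3,4-difluorophenyl in place of 4-methoxyphenyl on a carbonyl carbon. Within the data shown here, the only measured step, no change at the digits printed from compound 1 to compound 2 (within the scatter), likewise exchanged a group on the aryl ring attached to the carbonyl carbon and produced nothing beyond the scatter; no fluorinated analogue has been measured, and the guidance is loose. For compound 3 the expected step in this assay is a number 3 percentage points lower from compound 2 to compound 3 (within the scatter), none beyond the scatter. The estimate for compound 3 in this assay is 90%, within 72% to 100%.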

Compound 3, a percentage reported as activity, at one concentration (the size of the read-out at that concentration, not a potency): 97%
Beside the measured number, compound 3's estimate is 7 percentage points below it; measured number inside the range.
By their numbers in this assay, from the lowest: compounds 1, 2 and 3 (each within the scatter of the next).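

On the carbonyl carbon, 3,4-difluorophenyl gives no separation from either earlier aryl group in this assay, with a number 4 percentage points higher from compound 2 to compound 3 (within the scatter) and a number 4 percentage points higher from compound 1 to compound 3 (within the scatter). The flat result at this position now extends beyond 4-aminophenyl and 4-methoxyphenyl to an aryl group carrying fluorine and no hydrogen-bond acceptor, and compounds 1, 2 and 3 all remain at the weak end of the read-out at the one concentration tested. No supporting data bear on why this position stays flat.

From the compounds shown here alone, it remains open whether a non-aromatic group, such as a morpholine or a carboxylic acid on a short alkyl chain, would move the read-out if placed on the carbonyl carbon. The single concentration also leaves open whether these aryl groups would separate at higher concentrations.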